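Removing the trifluoromethoxy group: expected growth inhibition

The compounds below may be only part of what the source reports. "The series", "measured", "known", "first", "only" and "open" are said of these compounds alone.

Two substituted members of the series have numbers. Compound 1 `FC(F)(F)Oc1ccc(Cn2cc(CCCOc3cccc4cccnc34)nn2)cc1` carries a trifluoromethoxy group on its six-membered aromatic ring of carbon only; in a functional assay on 786-0 cells (Homo sapiens) for inhibition, read by sulforhodamine B assay, with a stated time of 48 h (a higher number here means a weaker inhibitor of growth, a lower number a stronger inhibitor of growth), compound 1 gives 7.9 ug/mL. Compound 2 `Clc1cc(Cl)c(Cn2cc(CCCOc3cccc4cccnc34)nn2)c(Cl)c1` carries chlorine substituents on that ring instead; in this assay compound 2 gives 5.6 ug/mL. Compound 1 holds the highest of the two numbers, yet its nearest neighbour, compound 2, lies within the scatter of it, so the two cannot be ordered.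

Compound 3 `c1ccc(Cn2cc(CCCOc3cccc4cccnc34)nn2)cc1` is the unsubstituted analogue. Relative to compound 1 the change is hydrogen in place of trifluoromethoxy on an aromatic carbon. For the measured compounds named here, no measured pair isolates this change, so the expectation rests only on the two values, which sit close together despite different substituents. A small step toward a higher number, around the edge of the scatter, is expected: a 1.4-fold higher number from compound 1 to compound 3 (0.14 log units; within the scatter). Compound 3 is therefore estimated at 11 ug/mL, with a range from 4.5 ug/mL to 28 ug/mL.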

Compound 3, concentration for 50% growth inhibition: 25 ug/mL
For compound 3 the middle estimate is 2.3-fold (0.36 log units) below the measured one; low and high end bracket the measured number.
By their numbers in this assay, from the lowest: compounds 2 and 1 (each within the scatter of the next); then compound 3.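

In this assay, the bare ring of compound 3 separates from the substituted compounds: taking away the trifluoromethoxy group gives a 3.2-fold higher number from compound 1 to compound 3 (0.50 log units; beyond the scatter), so this position is not indifferent to substitution. Replacing the 2,4,6-trichlorophenyl group with phenyl points the same way, with a 4.5-fold higher number from compound 2 to compound 3 (0.65 log units; beyond the scatter), so two quite different substitution patterns both give lower numbers than the unsubstituted ring. Nothing among the data explains why either group lowers the number relative to hydrogen.

Open, from the compounds shown here alone, is whether a single small group, such as one fluorine or one chlorine, on that aromatic carbon would be enough to match compound 1. Also open, going by these compounds, is how a methoxy group, an amine or a carboxylic acid at the same place would compare with hydrogen and trifluoromethoxy.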